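Swapping 2-Chloroethoxy for ((Chloromethyl)carbonyl)amino

The source may report more compounds than this note shows. Statements on the series, on what has been measured and on what is new or still open speak of the compounds shown alone.

Three compounds share one core and differ at one end group. Compound 1 `COC(=O)N1CCCc2cc(S(=O)(=O)N3CC(c4ccccc4)NC3=O)ccc21` gives only a limit in a functional assay on K562 cells (Homo sapiens) for antiproliferative activity, read by MTT assay (on this read-out higher numbers stand for weaker inhibition and lower numbers for stronger inhibition), > 20000 nM. Compound 2 `C=CCOC(=O)N1CCCc2cc(S(=O)(=O)N3CC(c4ccccc4)NC3=O)ccc21` gives 473 nM, and compound 3 `O=C(OCCCl)N1CCCc2cc(S(=O)(=O)N3CC(c4ccccc4)NC3=O)ccc21` gives 10600 nM, the higher of the two actual numbers. Compound 4 `O=C(CCl)NC(=O)N1CCCc2cc(S(=O)(=O)N3CC(c4ccccc4)NC3=O)ccc21` carries ((chloromethyl)carbonyl)amino in place of 2-chloroethoxy on a carbonyl carbon. Among the compounds with values here, no measured compound carries this new group, so the evidence is indirect. The nearest guide is the large step of a 22-fold higher number from compound 2 to compound 3 (1.35 log units; beyond the scatter), which shows that this end group can shift the number strongly. Compound 2 also shows that values far below compound 3 are reachable, with an at least 42-fold lower number from compound 1 to compound 2 (1.62 log units; beyond the scatter). The expected change is a 5.3-fold lower number from compound 3 to compound 4 (0.72 log units; beyond the scatter). For compound 4, the estimated value is 2000 nM, within an expected range of 200 nM to 15000 nM.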

Compound 4, half-maximal inhibitory concentration: 515 nM
For compound 4 the middle estimate is 3.9-fold (0.59 log units) above the measured one; measured number inside the range.
By their numbers in this assay, from the lowest: compounds 2 and 4 (each within the scatter of the next); then compound 3. At a limit, above all of these: compound 1.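

Two chlorine-bearing end groups on this carbonyl carbon can differ greatly, with a 21-fold lower number from compound 3 to compound 4 (1.31 log units; beyond the scatter), while ((chloromethyl)carbonyl)amino and allyloxy cannot be told apart, with a 1.1-fold higher number from compound 2 to compound 4 (0.04 log units; within the scatter); low numbers here are therefore not confined to allyloxy. Against methoxy, the change gives an at least 38-fold lower number from compound 1 to compound 4 (1.58 log units; beyond the scatter), which is only a floor for the true size of the step. Compound 1 gives only a limit, not a number: the limit of > 20000 nM in this assay, at which 1 of the 4 values shown sits.

Still open, on these data alone, is what an acetylamino group, the same end group without its chlorine, would give. As far as these compounds go, the effect of a longer chain carrying the chlorine also remains open.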